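Chloro for Methoxy on Two Related Cores

The source may report more compounds than this note shows. Statements on the series, on what has been measured and on what is new or still open speak of the compounds shown alone.

Compound 1 `C=C1C[C@]23C[C@@]1(O)CC[C@H]2c1ccc(OS(=O)(=O)c2ccc(C)cc2)c(C)c1[C@@H]3Cn1cc(-c2ccc(Cl)cc2)nn1`: > 20000 nM
Compound 2 `C=C1C[C@]23C[C@@]1(O)CC[C@H]2c1ccc(OS(=O)(=O)c2ccc(C)cc2)c(C)c1[C@@H]3Cn1cc(-c2ccc(OC)cc2)nn1`: > 20000 nM
Compound 3 `C=C1C[C@]23C[C@@]1(O)CC[C@@H]2c1cccc(C)c1[C@@H]3Cn1cc(-c2ccc(OC)cc2)nn1`: > 20000 nM

Of the compounds shown here, three have been tested in a functional assay on SMMC-7721 cells (Homo sapiens) for cytotoxicity, read by MTT assay, with a stated time of 4 days; on this read-out lower numbers stand for stronger inhibition and higher numbers for weaker inhibition. In this assay compound 1 gives > 20000 nM, which is a limit of the assay and not a number. Compound 2 gives > 20000 nM, again a limit. Compound 3 gives > 20000 nM, also a limit. All three values therefore sit at the limit of > 20000 nM in this assay, at which 3 of the 3 values shown sit.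

Compound 1 and compound 2 share one core and differ in a single place: chloro in place of methoxy on an aromatic carbon. The step that the two limits leave unreadable from compound 2 to compound 1 cannot be read, since both values are limits. Compound 3 carries a different core, and the difference between the two cores is not broken down here.

The unmeasured compound 4 `C=C1C[C@]23C[C@@]1(O)CC[C@@H]2c1cccc(C)c1[C@@H]3Cn1cc(-c2ccc(Cl)cc2)nn1` relates to compound 3 as compound 1 relates to compound 2: chloro in place of methoxy on an aromatic carbon. The surroundings of the change are the same in both pairs, so this is the same change made on the core of compound 3. Because compound 3 gives > 20000 nM, compound 4 is expected to remain at that limit as well. The expected step that the limit leaves unreadable from compound 3 to compound 4 is thus essentially nothing. The estimate for compound 4 is 30000 nM, with a range from 12000 nM to 100000 nM, and it will most likely again be reported only as a limit.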

Compound 4, half-maximal inhibitory concentration: > 20000 nM
Compound 4: only a limit was reported (the forecaster's own chance of this, stated with the estimate: 85%); the middle value lies beyond the limit too.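

In this assay compound 4 gives > 20000 nM as a limit of the assay and not a number. Compound 3 also stands at a limit, so no step can be read between compound 3 and compound 4. Still open is how strongly any of the four compounds acts on these cells, and whether chloro or methoxy matters on either core, with every value at one point: the limit of > 20000 nM in this assay, at which 4 of the 4 values shown sit.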